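Phenyl for dimethoxyphenyl on a silyl ether core

The compounds below may be only part of what the source reports. "The series", "measured", "known", "first", "only" and "open" are said of these compounds alone.

Compound 1 `COc1ccc(C2=C(c3cc(OC)c(OC)c(OC)c3)C(=O)CC2O[SiH2]C(C)(C)C)cc1OC` in an ADME assay on HEp-2 cells (Homo sapiens) for cytotoxicity, read by MTT assay, with a stated time of 72 h (a higher number here means a weaker inhibitor, a lower number a stronger inhibitor), gives > 100 ug/mL, which is a limit of the assay and not a number.
Compound 2 `COc1ccc(C2=C(c3cc(OC)c(OC)c(OC)c3)C(=O)CC2OC(C)=O)cc1NC=O` in this assay gives 3.27 ug/mL.
Compound 3 `CCOC(=O)COc1ccc(C2=C(c3cc(OC)c(OC)c(OC)c3)C(=O)CC2O)cc1` in this assay gives > 100 ug/mL, again only a limit.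

Compound 1 therefore stands at the weak end of what this assay can report, at the limit where two of the three values sit (the limit of > 100 ug/mL in this assay, at which 2 of the 3 values shown sit). Only compound 2 returns a number. For the measured compounds named here, no two of the measured compounds differ in just one place, so no measured step is available; of compound 1 and compound 2 the values show only that one is a limit and the other a number below it.

The unmeasured compound 4 `COc1cc(C2=C(c3ccccc3)C(O[SiH2]C(C)(C)C)CC2=O)cc(OC)c1OC` differs from compound 1 by phenyl in place of 3,4-dimethoxyphenyl on a double-bonded ring carbon. Going by the values given here, no measured pair speaks to this change, and the shared core with its silyl ether has so far given a limit only. The account therefore expects no step beyond the usual scatter in this assay, with compound 4 most likely also reported as a limit.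

Compound 4 is expected to give about 100 ug/mL in this assay, with a range from 30 ug/mL to 300 ug/mL. The expected step of a number no higher from compound 1 to compound 4 (the limit leaves the size open) is estimated to be flat.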

Compound 4, half-maximal inhibitory concentration: > 100 ug/mL
Compound 4: no number, only a limit; the forecaster's own chance of this, stated with the estimate: 65%; the middle value lies on the limit itself.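

In this assay compound 4 gives > 100 ug/mL, a limit of the assay and not a number. Compound 1 also stands at a limit, so no step between compound 1 and compound 4 can be read: the limit of > 100 ug/mL in this assay, at which 3 of the 4 values shown sit.

The compounds shown leave open whether phenyl in place of 3,4-dimethoxyphenyl on a double-bonded ring carbon changes the value at all.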